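A few compounds are considered here, and "the series" means these few. Any claim that something is new, unique, unknown or untested is made for them only; others in the source may bear on it.

Measured in a functional assay on A549 cells (Homo sapiens) for antiproliferative activity, read by MTT assay, with a stated time of 72 h; a higher number here means a weaker inhibitor, a lower number a stronger inhibitor:
- Compound 1 `Nc1nc(N)c2cc(CSC(=S)N3CCN(c4ccc(Cl)c(Cl)c4)CC3)ccc2n1`: 2940 nM
- Compound 2 `Nc1nc(N)c2cc(CSC(=S)N3CCN(c4ccccc4F)CC3)ccc2n1`: 6460 nM
- Compound 3 `CC(=O)c1ccc(N2CCN(C(=S)SCc3ccc4nc(N)nc(N)c4c3)CC2)cc1`: 2550 nM

Compound 3 sits at the stronger end of this small set, but it does not stand alone there. The step of a 1.2-fold lower number from compound 1 to compound 3 (0.06 log units; within the scatter) leaves compound 3 and compound 1 indistinguishable, whereas a 2.5-fold lower number from compound 2 to compound 3 (0.40 log units; beyond the scatter) sets compound 3 clearly apart from compound 2.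

Compound 4 `Nc1nc(N)c2cc(CSC(=S)N3CCN(c4ccccn4)CC3)ccc2n1` keeps the shared core and changes only the group on the piperazine-like ring, here called an amine nitrogen in a ring: pyridin-2-yl in place of 4-acetylphenyl. The counted change is pyridin-2-yl in place of 4-acetylphenyl on an amine nitrogen in a ring.

All three measured steps swap a group at this same place, so all of them bear on the question. They are small: a 2.2-fold higher number from compound 1 to compound 2 (0.34 log units; beyond the scatter) is modest, and the largest is a 2.5-fold lower number from compound 2 to compound 3 (0.40 log units; beyond the scatter). Among the measured compounds shown here, none of the measured compounds carries a pyridin-2-yl group, so the data give no direct reading for it. With compound 3 already at 2550 nM, the stronger end of the set, a swap here seems more likely to raise the number than to lower it, though only slightly.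

The expected change is a 1.6-fold higher number from compound 3 to compound 4 (0.20 log units; within the scatter), a small step upward at most. For compound 4 the estimated value is 4000 nM, with an expected range of 1800 nM to 9000 nM.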

Compound 4, half-maximal inhibitory concentration: 3960 nM
Estimate against measurement, compound 4: 1.0-fold (0.00 log units) above; the range from low to high includes it.
By their numbers in this assay, from the lowest: compounds 3, 1, 4 and 2 (each within the scatter of the next, the first and the last beyond it).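

In this assay, among the compounds shown here, the new step is the first at this place to bring a hetero atom into the aromatic ring, and pyridin-2-yl also has fewer heavy atoms than 4-acetylphenyl, yet the result is only a step within the scatter (a 1.6-fold higher number from compound 3 to compound 4 (0.19 log units; within the scatter)). The other two new steps are also within the scatter (a 1.6-fold lower number from compound 2 to compound 4 (0.21 log units; within the scatter) and a 1.3-fold higher number from compound 1 to compound 4 (0.13 log units; within the scatter)), so compound 4 cannot be told apart from any of the other three, even though compound 2 and compound 3 are separated from each other (a 2.5-fold lower number from compound 2 to compound 3 (0.40 log units; beyond the scatter)). This place on the ring nitrogen therefore accepts a ring nitrogen in the aromatic group with no readable loss of activity, and nothing available here offers an explanation for that.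

All four compounds carry a six-membered aromatic ring at this place, which leaves open what a saturated ring such as cyclohexyl or a small chain such as methyl would do. Going by these compounds, it also remains open whether pyridin-4-yl would read the same as pyridin-2-yl, and whether an amine or a carboxylic acid on the aromatic ring would move the number beyond the scatter.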